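This account rests on a few compounds, and the source may have more. Where it says the series, first, only, none or still open, it means among the compounds named here.

Measured so far:
- compound 1, `Nc1ccc2cccc(OC3CCCC3)c2n1`
- compound 2, `CCOCC(C)Oc1cccc2ccc(N)nc12`

In an assay on cells with melanin-concentrating hormone receptor 1 (Homo sapiens) as the target, read by radioligand binding (a lower number here means a stronger inhibitor, a higher number a weaker inhibitor), compound 1 gives only a limit, > 2000 nM. In this assay compound 2 gives 1070 nM. Compound 2 thus holds the only number shown in this assay; the other value shown is a limit. Among the measured compounds shown here, the one measured step, an at least 1.8-fold lower number from compound 1 to compound 2 (0.27 log units; that floor lies within the scatter), is read from that limit, so its true size is open, as the limit of > 2000 nM in this assay, at which 1 of the 2 values shown sits, records.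

Compound 3, `Nc1ccc2cccc(OCC3CCCO3)c2n1`, is reached from compound 2 by a group of 6 heavy atoms (5 carbon, 1 oxygen; one five-membered non-aromatic ring with 1 hetero atom) in place of a group of 6 heavy atoms (5 carbon, 1 oxygen; no ring), on an oxygen on an aromatic ring. For the measured compounds named here, the single step measured so far bears on it only loosely: it ran from a limit, and its floor lies within the scatter, so it gives no firm size for a change on this oxygen. No step beyond the scatter is therefore expected in this assay from compound 2 to compound 3, in either direction. Compound 3 is estimated at 1000 nM, with a range of 400 nM to 3000 nM, meaning an expected step of a 1.1-fold lower number from compound 2 to compound 3 (0.03 log units; within the scatter).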

Compound 3, half-maximal inhibitory concentration: > 2000 nM
Compound 3 gave a limit, no number (the forecaster's own chance of this, stated with the estimate: 25%); middle value at least 2.0-fold (0.30 log units) away from the limit.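

Putting (oxolan-2-yl)methyl in place of the open chain on an oxygen on an aromatic ring gives, in this assay, an at least 1.8-fold higher number from compound 2 to compound 3 (0.27 log units; that floor lies within the scatter), so this floor alone does not separate two groups that match in heavy atoms and hydrogen-bond acceptors. Compound 3 gives only a limit, > 2000 nM, and the step from compound 1 to compound 3 cannot be read, as both ends are limits. Both compounds with a ring in this group now end at a limit, and only the open chain of compound 2 gives a number, a pattern that rests on these compounds alone: the limit of > 2000 nM in this assay, at which 2 of the 3 values shown sit.

As far as these compounds go, how far compound 1 and compound 3 lie from their limits stays open, so the two rings cannot be ranked. Also open, from the compounds shown here alone, is whether a longer chain, or a chain ending in an amine, on this oxygen would lower the number in this assay.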